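The source may hold more compounds than are shown below. What is called first, only, known or untested is meant among the compounds shown, and "the series" means these compounds.

In a functional assay on the whole organism with Rattus norvegicus as the target (a higher number here means that more compound is needed for the effect, a lower number that less compound is needed), three compounds have been measured. For the measured compounds named here, compound 1 `CCOCCOC(=O)C(=O)Nc1nc(-c2cc(Br)no2)cs1` gives 11 mg/kg as the only true number among them. Compound 2 `O=C(Nc1nc(-c2cc(-c3c(F)cccc3Cl)no2)cs1)C(=O)OCc1ccccc1` carries a 2-chloro-6-fluorophenyl and reads > 30 mg/kg as a limit of the assay. Compound 3 `CCOCCOC(=O)C(=O)Nc1nc(-c2c(-c3ccccc3)noc2C)cs1` reads > 10 mg/kg as a limit too, so it stands without a number. Compound 4 `CCOCCOC(=O)C(=O)Nc1nc(-c2c(-c3c(F)cccc3Cl)noc2C)cs1` has 2-chloro-6-fluorophenyl in place of phenyl on an aromatic carbon and has not yet been measured. Going by the values given here, no measured pair shows such a change, so no step beyond the scatter is expected in this assay and no direction can be given. The expected step that the limit leaves unreadable from compound 3 to compound 4 is an estimate only. For compound 4 the estimated dose is 15 mg/kg with an expected range from 6 mg/kg to 40 mg/kg in this measurement.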

Compound 4, dose for half-maximal effect: > 10 mg/kg
Compound 4 gave a limit, no number; the forecaster's own chance of this, stated with the estimate: 50%; the middle value lies beyond the limit too.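

In this assay compound 3 and compound 4 both read only as limits, so no step can be read between them. The compounds shown leave open whether 2-chloro-6-fluorophenyl in place of phenyl changes the dose at all.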